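Aryl group back on the chain carbon

A few compounds are considered here, and "the series" means these few. Any claim that something is new, unique, unknown or untested is made for them only; others in the source may bear on it.

Compound 2 `CC(C)CCn1c(CN2CCN(C(=O)C3CC3)CC2)nc2ccccc21` gives the higher of the two numbers in an assay on isolated protein for inhibition of aldehyde dehydrogenase 1A1 (Homo sapiens), read by spectrophotometry, tested at 10 uM (on this read-out lower numbers stand for less inhibition and higher numbers for more inhibition at the one concentration tested (going by the name of the read-out)), at 70%; compound 1 `O=C(C1CC1)N1CCN(Cc2nc3ccccc3n2Cc2ccc(Cl)cc2)CC1` gives 56.6%. Among the compounds with values here, the one measured step, a number 13.4 percentage points higher from compound 1 to compound 2 (beyond the scatter), is the reverse of what is now proposed. Compound 3 `O=C(C1CC1)N1CCN(Cc2nc3ccccc3n2Cc2cccc(Cl)c2)CC1` carries 3-chlorophenyl in place of isobutyl on a saturated chain carbon bound to an aromatic nitrogen. Since compound 1 to compound 2 moved in the direction of more inhibition, compound 3 is expected to move back toward less, though the chlorine site differs from compound 1 and the step may be smaller; the expected shift is a number 10 percentage points lower from compound 2 to compound 3 (within the scatter). Compound 3 is thus estimated at 60%, within 45% to 75%.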

Compound 3, a percentage reported as inhibition, at one concentration (the size of the read-out at that concentration, not a potency): 71.6%
Beside the measured number, compound 3's estimate is 11.6 percentage points below it, within the range that was stated.
By their numbers in this assay, from the lowest: compound 1; then compounds 2 and 3 (each within the scatter of the next).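

In this assay, the saturated chain carbon bound to an aromatic nitrogen accepts 3-chlorophenyl as well as isobutyl, with a number 1.6 percentage points higher from compound 2 to compound 3 (within the scatter), so a chlorophenyl group here does not in itself go with less inhibition. What separates the two chlorophenyl groups is where the chlorine sits, with 3-chlorophenyl in place of 4-chlorophenyl giving a number 15 percentage points higher from compound 1 to compound 3 (beyond the scatter). No evidence is available to explain this difference. From the compounds shown here alone, whether the chlorine is needed at all remains open, as an unsubstituted phenyl would show, and so does how a methoxy group or a carboxylic acid on that ring would read out.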